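Replacing ethyl with acetyl in compound 3

This account rests on a few compounds, and the source may have more. Where it says the series, first, only, none or still open, it means among the compounds named here.

compound 1 `CCN1CCN(c2nc(C)nc3c2nc(-c2ccccc2Cl)n3C)CC1`: 30%
compound 2 `Cc1nc(N2CCN(C)CC2)c2nc(-c3ccccc3Cl)n(CCO)c2n1`: 6%
compound 3 `CCN1CCN(c2nc(C)nc3c2nc(-c2ccccc2Cl)n3CCOC)CC1`: 53%

In an ADME assay (liver) for metabolic stability, with Liver microsome (Rattus norvegicus) as the target, read by LC-MS, using microsomes, with a stated time of 30 min, tested at 4 uM (on this read-out lower numbers stand for a less stable compound and higher numbers for a more stable compound), compound 3 gives 53%, the highest of the three numbers, ahead of compound 1 at 30% and compound 2 at 6%. Compound 4 `COCCn1c(-c2ccccc2Cl)nc2c(N3CCN(C(C)=O)CC3)nc(C)nc21` departs from compound 3 in one place: acetyl in place of ethyl on an amine nitrogen in a ring. This puts acetyl in place of ethyl on an amine nitrogen in a ring. Among the measured compounds shown here, no measured step covers that change. The only one available, a number 23 percentage points higher from compound 1 to compound 3 (beyond the scatter), lies elsewhere in the structure and can serve only as a rough gauge of size, and the data do not fix a direction. A modest rise is tentatively expected, a number 9 percentage points higher from compound 3 to compound 4 (within the scatter). For compound 4 the estimate is 62%, with the expected range running from 35% to 85%.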

Compound 4, percent of the compound remaining: 95%
Estimate against measurement, compound 4: 33 percentage points below; measured number outside the range, above it.
By their numbers in this assay, from the lowest: compound 2; then compound 1; then compound 3; then compound 4.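

In this assay, the ring amine nitrogen proves to be a sensitive position: 4-acetylpiperazin-1-yl in place of 4-ethylpiperazin-1-yl gives a number 42 percentage points higher from compound 3 to compound 4 (beyond the scatter), a large step. The earlier one-place step had shown a change only on the aromatic nitrogen, so this is the first measured effect at the ring nitrogen. Nothing available explains the rise.

As far as these compounds go, it remains open whether a propionyl or methanesulfonyl group on that ring nitrogen would give a similar number. It is also unknown whether acetyl would produce a step of similar size on the core of compound 1.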